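The source may report more compounds than this note shows. Statements on the series, on what has been measured and on what is new or still open speak of the compounds shown alone.

Measured compounds:
Compound 1, `COc1cc(-n2ncnc2-c2ccc(C)cc2)cc(OC)c1OC`, gives 250 nM in a functional assay on HeLa cells (Homo sapiens) for antiproliferative activity, read by MTT assay, with a stated time of 72 h; a higher number here means a weaker inhibitor, a lower number a stronger inhibitor.
Compound 2, `CCOc1cccc(-c2ncnn2-c2cc(OC)c(OC)c(OC)c2)c1`, gives > 10000 nM in this assay.

Going by the values given here, compound 1 holds the only number among the two values shown. The value of compound 2 is a limit of the assay and not a number, so compound 2 stands at the limit of > 10000 nM in this assay, at which 1 of the 2 values shown sits. Among the compounds with values here, with no step between two measured compounds on record, nothing shows how much a change of the aromatic group on the five-membered ring shifts the result.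

Compound 3, `COc1cc(-n2ncnc2-c2ccc(Cl)c(Cl)c2)cc(OC)c1OC`, differs from compound 1 in one place: 3,4-dichlorophenyl in place of 4-methylphenyl on an aromatic carbon. Within the data shown here, since no measured step covers such an exchange, the size of the effect in this assay can only be guessed; the expectation is a step toward a weaker inhibitor, larger than the usual scatter, though a value within scatter of compound 1 cannot be excluded. The expected step from compound 1 to compound 3 is a 6.0-fold higher number from compound 1 to compound 3 (0.78 log units; beyond the scatter). Compound 3 is therefore estimated at 1500 nM, with a range from 400 nM to 8000 nM.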

Compound 3, half-maximal inhibitory concentration: > 10000 nM
Compound 3: a limit, no number; the forecaster's own chance of this, stated with the estimate: 15%; middle value at least 6.6-fold (0.82 log units) away from the limit.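

Going by these compounds alone, exchanging 4-methylphenyl for 3,4-dichlorophenyl on this aromatic carbon of the five-membered ring provides the first measured step in this assay, and it is large: an at least 40-fold higher number from compound 1 to compound 3 (1.60 log units; beyond the scatter). Within the data shown here, compound 3 gives a limit of the assay and not a number, so the step has a lower bound but no exact size: the limit of > 10000 nM in this assay, at which 2 of the 3 values shown sit. The earlier compounds could not show that this position responds so strongly, but this pair shows that changing only the aromatic group, with the rest of compound 1 kept, is enough to move the result from a measured number to the limit.

This single exchange cannot separate the loss of the methyl group from the gain of either chlorine atom, so it remains unclear which part of the change matters. Going by these compounds, how a plain phenyl ring, or a phenyl ring carrying an amine or a hydroxyl group, would behave at this carbon also remains open, and so does whether any such group could give a lower number than compound 1 does.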